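A few compounds are considered here, and "the series" means these few. Any claim that something is new, unique, unknown or untested is made for them only; others in the source may bear on it.

Measured compounds:
- compound 1, `COc1ccc(-c2cc(=O)c3c(OC)cc(OC)cc3[nH]2)cc1`: > 31100 nM
- compound 2, `COc1ccc(-c2c(Br)c(=O)c3c(OC)cc(OC)cc3n2S(=O)(=O)c2ccc(OC)cc2)cc1`: "not determined" (no result reported)

Compound 1 was tested in a functional assay on UoC-B1 cells (Homo sapiens) for antiproliferative activity, with a stated time of 72 h (a lower number here means that less compound is needed, a higher number that more compound is needed for the effect), and gave only a limit of the assay, > 31100 nM. Going by the values given here, compound 2, which carries a (4-methoxyphenyl)sulfonyl group on the ring nitrogen and a bromo group on the core, has no reported number in this assay, so where it stands can only be read from the single value shown: the limit of > 31100 nM in this assay, at which 1 of the 2 values shown sits, which is a limit and not a number. Among the compounds with values here, no step between measured compounds can therefore be given.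

Compound 3, `COc1ccc(-c2c(I)c(=O)c3c(OC)cc(OC)cc3n2S(=O)(=O)c2ccc(OC)cc2)cc1`, differs from compound 2 by iodo in place of bromo on an aromatic carbon. As compound 2 offers no number to start from, the size and direction of this step in this assay cannot be read off, and a change of one halogen for another of this kind is expected to stay within the usual scatter rather than beyond it. Compound 3 is estimated to give about 8000 nM in this assay, with an expected range from 800 nM to 40000 nM, and a substantial chance that only a limit is reported.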

Compound 3, half-maximal effective concentration: 2550 nM
Compound 3: the middle estimate sits 3.1-fold (0.50 log units) above what was measured; the measured number falls inside the stated range.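

No step can be read between compound 2 and compound 3, as compound 2 offers no number in this assay to set beside the value of compound 3. The compounds shown leave open what iodo in place of bromo on an aromatic carbon does in this assay, in size or in direction.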